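Cytotoxicity Limits Before and After a Chloro Swap

The compounds below may be only part of what the source reports. "The series", "measured", "known", "first", "only" and "open" are said of these compounds alone.

Compound 1 `O=C(CN1CCN(c2ccccc2)CC1)N1CCN(c2nnc(-c3ccccc3)c(-c3ccccc3)n2)CC1`: in an ADME assay on NIH3T3 cells (Mus musculus) for cytotoxicity, read by MTT assay, with a stated time of 24 h (a lower number here means a stronger inhibitor, a higher number a weaker inhibitor), compound 1 gives > 963000 nM, a limit of the assay.
Compound 2 `COc1ccc(-c2nnc(N3CCN(C(=O)CN4CCN(c5ccccc5)CC4)CC3)nc2-c2ccc(OC)cc2)cc1`: in this assay compound 2 gives > 863000 nM, also a limit.
Compound 3 `COc1ccc(-c2nnc(N3CCN(C(=O)CN4CCN(c5ccccc5OC)CC4)CC3)nc2-c2ccc(OC)cc2)cc1`: in this assay compound 3 gives > 821000 nM, again a limit.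

None of the three values is a number; all three are limits, and compound 3 therefore stands only at the limit of > 821000 nM in this assay, at which 1 of the 3 values shown sits. Going by the values given here, the one measured step is a step that the two limits leave unreadable from compound 2 to compound 3; both of its ends are limits, so its size is not readable. Compound 4 `COc1ccc(-c2nnc(N3CCN(C(=O)CN4CCN(c5ccccc5Cl)CC4)CC3)nc2-c2ccc(OC)cc2)cc1` differs from compound 3 by chloro in place of methoxy on an aromatic carbon. Among the compounds with values here, no measured step involves this exchange, and the nearest step was unreadable, so no step beyond the scatter is expected in this assay. Compound 4 is expected to give 850000 nM in this assay, between 300000 nM and 2500000 nM, most likely reported once more as a limit. The expected step that the limit leaves unreadable from compound 3 to compound 4 is essentially none.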

Compound 4, half-maximal inhibitory concentration: > 814000 nM
Compound 4 was reported as a limit; the forecaster's own chance of this, stated with the estimate: 85%; the middle value does not contradict the limit.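

In this assay compound 4 gives > 814000 nM, a limit. Compound 2 and compound 3 are also limits, so neither step to compound 4 can be read. The compounds shown leave open what true half-maximal concentration, if any, compound 1, compound 2, compound 3 or compound 4 has in this assay.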